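Hydrogen in place of fluoro on compound 1

The source may hold more compounds than are shown below. What is called first, only, known or untested is meant among the compounds shown, and "the series" means these compounds.

Measured in a functional assay on the whole organism with Mus musculus as the target; a higher number here means that more compound is needed for the effect, a lower number that less compound is needed:
Compound 1 `Cn1nc(-c2ccc(F)cc2F)n(C)c1=S`: 2.37 mg/kg
Compound 2 `Fc1ccc(-c2n[nH]c(S)n2)cc1`: > 200 mg/kg
Compound 3 `CCn1c(-c2ccccc2)nn(C)c1=S`: 1.2 mg/kg

Among the compounds with values here, compound 1 has only one numerical neighbour in this assay. Compound 1 at 2.37 mg/kg and compound 3 at 1.2 mg/kg lie within the scatter of each other. Compound 2 gives no number, only a limit of the assay: it sits at the limit of > 200 mg/kg in this assay, at which 1 of the 3 values shown sits.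

The next compound to be measured is compound 4 `Cn1nc(-c2ccc(F)cc2)n(C)c1=S`. Compared with compound 1, it carries hydrogen in place of fluoro on an aromatic carbon. The other fluoro group stays in place. Within the data shown here, no measured pair isolates this change, so the expectation rests on indirect evidence. Compound 3 has no fluoro group on its aromatic ring and gives 1.2 mg/kg, but it also differs from compound 1 elsewhere and is therefore only a loose guide. On that basis, no step beyond the scatter is expected in this assay, and neither direction is favoured. The expected change is a 1.2-fold lower number from compound 1 to compound 4 (0.07 log units; within the scatter), which is estimated to stay within the scatter. For compound 4 the estimated value is 2 mg/kg, with an expected range from 0.7 mg/kg to 6.5 mg/kg.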

Compound 4, dose for half-maximal effect: 1 mg/kg
Compound 4: middle estimate off by 2.0-fold (0.30 log units), on the high side, and the stated range covers the measured number.
By their numbers in this assay, from the lowest: compounds 4, 3 and 1 (each within the scatter of the next, the first and the last beyond it). At a limit, above all of these: compound 2.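

In this assay, hydrogen in place of the fluoro group that is ortho to a group of 8 heavy atoms and meta to a fluoro group gives a 2.4-fold lower number from compound 1 to compound 4 (0.37 log units; beyond the scatter). Within the data shown here, this is the first step that isolates a single change, and it shows that the fluoro group at this position is not needed for the effect: compound 4 keeps its activity without it, and the step runs towards less compound being needed. Nothing available on the properties of these compounds bears on this step, so the data give no reason for it.

The read applies to this one position only, since compound 4 still carries its other fluoro group and no compound shown isolates that group. Also open, on these data alone, is how a chloro group, a methoxy group or an amine at the position now carrying hydrogen would read in this assay, and so whether the step reflects the loss of fluoro specifically or would recur with other groups there.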